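This account rests on a few compounds, and the source may have more. Where it says the series, first, only, none or still open, it means among the compounds named here.

In an ADME assay on MT4 cells (Homo sapiens) for cytotoxicity, read by MTT assay, with a stated time of 96 h (a lower number here means that less compound is tolerated, a higher number that more compound is tolerated), compound 1 (`Cc1cccc(C2CC(c3ccc(Oc4ccccc4)cc3)=NN2c2ccc(S(N)(=O)=O)cc2)c1`) gives 35000 nM and compound 2 (`Cc1cccc(C2CC(c3ccccc3)=NN2c2ccc(S(N)(=O)=O)cc2)c1`) gives 37000 nM while compound 3 (`Cc1cccc(C2CC(c3ccc(OCc4ccccc4)cc3)=NN2c2ccc(S(N)(=O)=O)cc2)c1`) gives 44000 nM and so compound 1 stands within the scatter of both others. Compound 4 (`NS(=O)(=O)c1ccc(N2N=C(c3ccc(Oc4ccccc4)cc3)CC2c2cccc(Cl)c2)cc1`) differs from compound 1 in one place (chloro in place of methyl on an aromatic carbon): chloro in place of methyl on an aromatic carbon, meta to a large group. Going by the values given here, no measured step touches that place, and no measured compound carries chloro. The three available steps exchange hydrogen, phenoxy and benzyloxy at a different place (a 1.1-fold higher number from compound 1 to compound 2 (0.02 log units; within the scatter)) and (a 1.3-fold higher number from compound 1 to compound 3 (0.10 log units; within the scatter)) and (a 1.2-fold higher number from compound 2 to compound 3 (0.08 log units; within the scatter)) and each lies within the scatter, so they bear on the change only indirectly. Going by those small steps, and with compound 1 at 35000 nM as the starting value, no step beyond the scatter is expected in this assay for this change. The expected step is (no change at the digits printed from compound 1 to compound 4 (within the scatter)) and no larger. Compound 4 is estimated at 35000 nM with an expected range from 17000 nM to 70000 nM in this measurement.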

Compound 4, half-maximal cytotoxic concentration: 8000 nM
The estimate for compound 4 lay 4.4-fold (0.64 log units) above the measured number; measured number below the stated range.
By their numbers in this assay, from the lowest: compound 4; then compounds 1, 2 and 3 (each within the scatter of the next).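

In this assay, the change from 3-methylphenyl to 3-chlorophenyl gives a 4.4-fold lower number from compound 1 to compound 4 (0.64 log units; beyond the scatter), the only step among these compounds that lies beyond the scatter. Compounds 1, 2 and 3 exchange hydrogen, phenoxy and benzyloxy at a different place and stay within the scatter of one another, whereas here an exchange of one heavy atom for one heavy atom on the other aromatic ring moves the number beyond it. Nothing measured here accounts for this step.

The compounds shown leave open whether the step tracks the arrival of chloro or the departure of methyl, as hydrogen, fluoro, methoxy and an amine do not appear at this position among them. As far as these compounds go, it also remains open whether chloro gives a similar step alongside the hydrogen of compound 2 or the benzyloxy of compound 3.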